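This account rests on a few compounds, and the source may have more. Where it says the series, first, only, none or still open, it means among the compounds named here.

Measured compounds:
- compound 1 `COc1cc(C2Oc3cc([C@H]4Oc5cc(O)cc(O)c5C(=O)[C@@H]4O)ccc3OC2COC(=O)c2cccc(Cl)c2)ccc1O`: in a functional assay on liver (Rattus norvegicus, strain Sprague-Dawley) for inhibition, with a stated time of 1 h (on this read-out lower numbers stand for stronger inhibition and higher numbers for weaker inhibition), compound 1 gives 14200 nM
- compound 2 `COc1cc(C2Oc3cc([C@H]4Oc5cc(O)cc(O)c5C(=O)[C@@H]4O)ccc3OC2COC(=O)c2cc([N+](=O)[O-])cc([N+](=O)[O-])c2)ccc1O`: in this assay compound 2 gives 14600 nM

Within the data shown here, compound 1 stands level with compound 2, the only other measured compound: the step of a 1.0-fold higher number from compound 1 to compound 2 (0.01 log units; within the scatter) is within the scatter. Compound 3 `COc1cc(C2Oc3cc([C@H]4Oc5cc(O)cc(O)c5C(=O)[C@@H]4O)ccc3OC2COC(=O)/C=C/c2ccc(Br)cc2)ccc1O` differs from compound 1 by 2-(4-bromophenyl)ethenyl in place of 3-chlorophenyl on a carbonyl carbon. Among the measured compounds shown here, the one measured step, from compound 1 to compound 2, also exchanges the group on that carbonyl carbon and left the number essentially unchanged, so it bears on the present change only by analogy. For compound 3 a step within the scatter is expected, a 1.0-fold lower number from compound 1 to compound 3 (0.01 log units; within the scatter). Compound 3 is therefore estimated at 14000 nM, within 6000 nM to 35000 nM.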

Compound 3, half-maximal inhibitory concentration: 16300 nM
For compound 3 the middle estimate is 1.2-fold (0.07 log units) below the measured one; the range from low to high includes it.
By their numbers in this assay, from the lowest: compounds 1, 2 and 3 (each within the scatter of the next).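

This position on the carbonyl carbon also takes 2-(4-bromophenyl)ethenyl, which brings a double bond outside the aromatic ring, with no step beyond the scatter in this assay (a 1.1-fold higher number from compound 1 to compound 3 (0.06 log units; within the scatter); a 1.1-fold higher number from compound 2 to compound 3 (0.05 log units; within the scatter)). Across 3-chlorophenyl, 3,5-dinitrophenyl and 2-(4-bromophenyl)ethenyl, the number has not yet separated at this position. Still open, on these data alone, is whether a group carrying an amine or a carboxylic acid, or a longer saturated chain, on this carbonyl carbon would shift the number. Nothing available bears on why the values stay level.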